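From a Nitro Group to a Chloro Group on the Pendant Ring

This account rests on a few compounds, and the source may have more. Where it says the series, first, only, none or still open, it means among the compounds named here.

Compound 3 `O=[N+]([O-])c1ccc(C2=NN(C(=S)Nc3ccccc3)C(c3ccc4c(c3)OCCO4)C2)cc1` gives 105000 nM in a functional assay on WM 266-4 cells (Homo sapiens) for antiproliferative activity, read by MTT assay, with a stated time of 48 h (a higher number here means a weaker inhibitor of growth, a lower number a stronger inhibitor of growth), the second highest of the three numbers. Compound 2 `CSc1ccc(C2=NN(C(=S)Nc3ccccc3)C(c3ccc4c(c3)OCCO4)C2)cc1` gives 197000 nM, and a 1.9-fold lower number from compound 2 to compound 3 (0.27 log units; within the scatter). Compound 1 `S=C(Nc1ccccc1)N1N=C(c2ccc(Br)cc2)CC1c1ccc2c(c1)OCCO2` gives 870 nM; a 120-fold higher number from compound 1 to compound 3 (2.08 log units; beyond the scatter) and a 230-fold higher number from compound 1 to compound 2 (2.35 log units; beyond the scatter). Compound 4 `S=C(Nc1ccccc1)N1N=C(c2cccc(Cl)c2)CC1c1ccc2c(c1)OCCO2` differs from compound 3 in that (3-chlorophenyl in place of 4-nitrophenyl on a carbon with a double bond to nitrogen). The change bears on the step of a 120-fold higher number from compound 1 to compound 3 (2.08 log units; beyond the scatter) read backwards, because compound 1 gives 870 nM with a halogen on that ring, although compound 1 carries 4-bromophenyl and compound 4 carries 3-chlorophenyl. A large lowering in this assay is therefore expected, with some uncertainty. Compound 4 is estimated at 5000 nM, between 800 nM and 40000 nM, an expected step of a 21-fold lower number from compound 3 to compound 4 (1.32 log units; beyond the scatter).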

Compound 4, concentration for 50% growth inhibition: > 200000 nM
Compound 4 was reported as a limit (the forecaster's own chance of this, stated with the estimate: 5%); at least 40-fold (1.60 log units) between middle value and limit.
By their numbers in this assay, from the lowest: compound 1; then compounds 3 and 2 (each within the scatter of the next). At a limit, above all of these: compound 4.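

Compound 4 stands as a limit, not a number: the limit of > 200000 nM in this assay, at which 1 of the 4 values shown sits. A halogen on this ring does not by itself keep the growth inhibition of compound 1, as 3-chlorophenyl in place of 4-bromophenyl gives an at least 220-fold higher number from compound 1 to compound 4 (2.36 log units; beyond the scatter). The steps of an at least 1.9-fold higher number from compound 3 to compound 4 (0.27 log units; that floor lies within the scatter) and an at least 1.0-fold higher number from compound 2 to compound 4 (0.00 log units; that floor lies within the scatter) set no order for compound 4 against compounds 2 and 3.

The compounds shown do not separate the change of halogen from the change of its place on the ring. As far as these compounds go, how an amine or a carboxylic acid on this ring would read also stays open.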